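The source may hold more compounds than are shown below. What is called first, only, known or untested is meant among the compounds shown, and "the series" means these compounds.

This study follows how long compounds survive in an ADME assay on microsomes from liver (Mus musculus) for metabolic stability; a higher number here means that the compound lasts longer, a lower number that the compound disappears faster. Compound 1 `CCn1ncc2c(F)cc(-c3ccc(C(CC)(CC)c4nnc(C)[nH]4)c(=O)[nH]3)cc21` reaches the upper limit of the assay, and its result in this assay is recorded as > 3 h, a limit rather than a number. Compound 2 `CCn1ncc2c(F)cc(-c3ccc(C(CC)(CC)c4nncn4C)c(=O)[nH]3)cc21` likewise reaches a limit, giving > 3 h in this assay. Because both sit at a limit (the limit of > 3 h in this assay, at which 2 of the 3 values shown sit), the step that the two limits leave unreadable from compound 1 to compound 2 cannot be sized. Going by the values given here, compound 3 `CC(C)C(c1ccc(-c2ccc3cccc(F)c3c2)[nH]c1=O)N1CCCCC1=O` is the only one with a real number: in this assay compound 3 gives 0.0967 h, a short half-life.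

Compound 4 `CC(C)C(CC(N)=O)c1ccc(-c2ccc3cccc(F)c3c2)[nH]c1=O` differs from compound 3 in one place: carbamoylmethyl in place of 2-oxopiperidin-1-yl on a saturated chain carbon bound to an aromatic carbon and a saturated chain carbon. Among the compounds with values here, no measured step concerns this kind of change; the only step between measured compounds, from compound 1 to compound 2, alters a triazolyl group and is unreadable, so it offers no guide. The expectation for compound 4 therefore rests on compound 3 alone, whose half-life of 0.0967 h is the starting point. The step is estimated as a 1.6-fold higher number from compound 3 to compound 4 (0.19 log units; within the scatter), within the usual scatter. Compound 4 is expected to give about 0.15 h in this assay, with a plausible range from 0.04 h to 0.6 h.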

Compound 4, half-life: < 0.0667 h
Compound 4: no number, only a limit; the forecaster's own chance of this, stated with the estimate: 5%; at least 2.2-fold (0.35 log units) between middle value and limit.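

On the saturated chain carbon bound to an aromatic carbon and a saturated chain carbon, putting carbamoylmethyl in place of 2-oxopiperidin-1-yl gives an at least 1.4-fold lower number from compound 3 to compound 4 (0.16 log units; that floor lies within the scatter) in this assay. Going by these compounds alone, this is the first readable step in the study, and it shows that trading the ring for an open chain with a hydrogen-bond donor does not lengthen the half-life at this position, although the floor of the step alone does not separate the two compounds beyond the usual scatter. The result for compound 4 is a limit and not a number, so the real size of the step remains unknown: the limit of < 0.0667 h in this assay, at which 1 of the 4 values shown sits.

From the compounds shown here alone, whether any drop comes from losing the ring or from gaining the amide hydrogen remains open, as this single change does both at once. An amine or a carboxylic acid on the same carbon, or a longer chain ending in the same carbamoyl group, would be needed to tell whether any group at this position can carry the half-life away from this short end of the range.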